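The source may report more compounds than this note shows. Statements on the series, on what has been measured and on what is new or still open speak of the compounds shown alone.

Compound 1 `CC[C@@H]1C(=O)N(C)c2cnc(-n3ccc4cc(C(=O)NC)ccc43)nc2N1C1CCCC1` gives 8.6 nM in an assay for inhibition of serine/threonine-protein kinase PLK2 (Homo sapiens), read by FRET and Z'-LYTE, with a stated time of 1 h; on this read-out higher numbers stand for weaker inhibition and lower numbers for stronger inhibition. Compound 2 `CCCNC(=O)c1ccc2c(ccn2-c2ncc3c(n2)N(C2CCCC2)[C@H](CC)C(=O)N3C)c1` gives 11.4 nM in this assay; the change hydrogen in place of ethyl on a saturated chain carbon bound to an amide-type nitrogen made a 1.3-fold lower number from compound 2 to compound 1 (0.12 log units; within the scatter). Compound 3 `CCCCNC(=O)c1ccc2c(ccn2-c2ncc3c(n2)N(c2ccn(C)n2)C(CC)C(=O)N3C)c1` has a different core from compound 2, and the difference between the two cores is not broken down here; compound 3 gives 159 nM in this assay. Compound 4 `CCNC(=O)c1ccc2c(ccn2-c2ncc3c(n2)N(c2ccn(C)n2)C(CC)C(=O)N3C)c1` has not been measured; it differs from compound 3 by hydrogen in place of ethyl on a saturated chain carbon, two bonds along the chain from an amide-type nitrogen. Among the compounds with values here, this is the same kind of change as the one between compound 2 and compound 1, not the same: there the place was on a saturated chain carbon bound to an amide-type nitrogen, here it is two bonds along the chain from an amide-type nitrogen. For compound 4 the expected step is a 1.2-fold lower number from compound 3 to compound 4 (0.09 log units; within the scatter), which rests on the earlier step of a 1.3-fold lower number from compound 2 to compound 1 (0.12 log units; within the scatter) lying within the scatter. Compound 4 is estimated at 130 nM in this assay, with a range from 60 nM to 300 nM.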

Compound 4, half-maximal inhibitory concentration: 243 nM
The estimate for compound 4 lay 1.9-fold (0.27 log units) below the measured number, and the stated range covers the measured number.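

In this assay, going from butyl to ethyl gives a 1.5-fold higher number from compound 3 to compound 4 (0.18 log units; within the scatter). Set beside the earlier step, this change shows no difference between the two cores: the same change on two cores in this assay, a 1.3-fold lower number (0.12 log units; within the scatter) from compound 2 to compound 1 and a 1.5-fold higher number (0.18 log units; within the scatter) from compound 3 to compound 4, 2.0-fold (0.31 log units) apart, within the scatter of two such steps. This supports carrying the change between these two cores as a small step, but with one pair on each core and both steps within the scatter, it gives no direction for the change and no rule for any other core.

The compounds shown leave open whether a much longer chain at this place would move the number beyond the scatter on either core. They also leave open what an amine or a carboxylic acid at the end of the chain would do.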